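A few compounds are considered here, and "the series" means these few. Any claim that something is new, unique, unknown or untested is made for them only; others in the source may bear on it.

Of the compounds shown here, two sharing one core have been tested in an in vitro functional assay on RBL cells for antagonist activity at C-C chemokine receptor type 8 (Homo sapiens), read by FLIPR and calcium flux; on this read-out higher numbers stand for weaker inhibition and lower numbers for stronger inhibition. Compound 1 `COc1ccc2nccc(C3CN(C4CCCCN(Cc5cc6ccccc6[nH]5)C4)C(=O)O3)c2c1` gives only a limit of the assay, < 50200 nM, and no number. For the measured compounds named here, compound 2 `COc1ccc2nccc(C3CN(C4CCN(Cc5cc6ccccc6o5)CC4)C(=O)O3)c2c1` gives 1260 nM, the only number measured so far. Compound 3 `COc1ccc2nccc(C3CN(C4CCN(Cc5ccccc5Cl)CC4)C(=O)O3)c2c1` is not yet measured and differs from compound 2 by 2-chlorophenyl in place of 1-benzofuran-2-yl on a saturated chain carbon bound to an amine nitrogen in a ring. Going by the values given here, no measured step of this kind exists here, so in this assay a modest change is expected, possibly toward weaker inhibition, but it may stay within the scatter. Compound 3 is expected near 2000 nM, in a range from 600 nM to 6300 nM. This estimate means an expected step of a 1.6-fold higher number from compound 2 to compound 3 (0.20 log units; within the scatter).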

Compound 3, half-maximal inhibitory concentration: < 50200 nM
Compound 3: a limit, no number; the forecaster's own chance of this, stated with the estimate: 10%; the middle value does not contradict the limit.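

For the compounds shown here, compound 3 gives a limit and no number, so no step from compound 2 to compound 3 can be read: the limit of < 50200 nM in this assay, at which 2 of the 3 values shown sit. The compounds shown leave open how 2-chlorophenyl in place of 1-benzofuran-2-yl changes inhibition.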